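A few compounds are considered here, and "the series" means these few. Any claim that something is new, unique, unknown or untested is made for them only; others in the source may bear on it.

Measured so far:
Compound 1, `CCOC(=O)CC(=O)N1CCSC1COc1ccccc1OC`: 21 mg/kg
Compound 2, `CCOC(=O)CC(=O)N1CCS[C@H]1COc1ccccc1OC`: 448 mg/kg

Both numbers come from a functional assay on the whole organism for inhibition, with Cavia porcellus as the target; on this read-out higher numbers stand for an effect only at larger amounts of compound and lower numbers for an effect already at smaller amounts. Compound 2 stands at the higher of the two, with a 21-fold higher number from compound 1 to compound 2 (1.33 log units; beyond the scatter) separating it from compound 1. The two compounds share every atom and bond; the one thing that sets them apart is that the ring stereocentre is drawn without a configuration in compound 1 and as S in compound 2, so the large step can be read in the light of the fact that one of compounds 1 and 2 is drawn with a defined configuration and the other without, at the place where they differ: compound 1 covers both configurations, compound 2 only one of them.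

Compound 3, `CCOC(=O)CC(=O)N1CCS[C@@H]1COc1ccccc1OC`, is the other single configuration. the two compounds have the same atoms and bonds and differ only in configuration as drawn: 1 of 1 stereo elements differ; a stereocentre at a saturated ring carbon is drawn S in compound 2 and R in compound 3

Among the measured compounds shown here, only the step from compound 1 to compound 2 bears on this change, and it was large. If a mixture of both configurations gives the low number of compound 1 while the S configuration alone gives the high number of compound 2, the R configuration alone is expected to give a low number, with a 37-fold lower number from compound 2 to compound 3 (1.57 log units; beyond the scatter) in this assay. For compound 3 the expected result is 12 mg/kg, between 5 mg/kg and 40 mg/kg.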

Compound 3, dose for half-maximal effect: 41 mg/kg
The estimate for compound 3 lay 3.4-fold (0.53 log units) below the measured number, outside the stated range (above it).
By their numbers in this assay, from the lowest: compounds 1 and 3 (each within the scatter of the next); then compound 2.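

In this assay, the two single configurations are now seen side by side, separated by an 11-fold lower number from compound 2 to compound 3 (1.04 log units; beyond the scatter), and nothing but the drawn configuration at the ring carbon distinguishes them: the fact that compounds 2 and 3 differ only in the configuration as drawn

Compound 1 and compound 2 alone could not show how the R form behaves. The result places it level with the compound drawn without a configuration, with a 2.0-fold higher number from compound 1 to compound 3 (0.29 log units; within the scatter), so these two cannot be told apart here, and the S form, compound 2, is the least potent of the three.

All three compounds share the same atoms and bonds, so they say nothing about how far this gap between the R and S forms depends on the rest of the molecule. From the compounds shown here alone, it remains open whether the gap would persist with a carboxylic acid in place of the ester, or with a longer chain in place of the methoxy group.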